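A few compounds are considered here, and "the series" means these few. Any claim that something is new, unique, unknown or untested is made for them only; others in the source may bear on it.

Three compounds have been measured in a functional assay on PC-12 cells (Rattus norvegicus) for cytotoxicity, read by MTT assay, with stated times of 2 h and 24 h, tested at 1 uM; a higher number here means a stronger effect of the compound at the concentration tested, a lower number a weaker effect:

Compound 1, `Oc1cc(C(F)(F)F)ccc1-c1nc(-c2ccccc2O)n(-c2ccc(C(F)(F)F)cc2)n1`, gives 70.7%.
Compound 2, `COc1ccc(-n2nc(-c3ccc(C(F)(F)F)cc3O)nc2-c2ccccc2O)cc1`, gives 69%.
Compound 3, `Oc1cc(C(F)(F)F)ccc1-c1nc(-c2ccccc2O)n(-c2ccccc2C(F)(F)F)n1`, gives 71%.

The three share a core and differ only at its edges. Compound 2 differs from compound 1 by methoxy in place of trifluoromethyl on an aromatic carbon, and this change gave a number 1.7 percentage points lower from compound 1 to compound 2 (within the scatter). Compound 3 differs from compound 1 by 2-(trifluoromethyl)phenyl in place of 4-(trifluoromethyl)phenyl on an aromatic nitrogen, a change that gave a number 0.3 percentage points higher from compound 1 to compound 3 (within the scatter). Between the other pair, a number 2 percentage points higher from compound 2 to compound 3 (within the scatter). All three numbers sit within the scatter of one another, so none of them can be called stronger or weaker than the others in this assay.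

Compound 4, `COc1ccccc1-n1nc(-c2ccc(C(F)(F)F)cc2O)nc1-c1ccccc1O`, has not yet been measured. It differs from compound 3 by methoxy in place of trifluoromethyl on an aromatic carbon. For the measured compounds named here, this is the same kind of change as the one from compound 1 to compound 2, but the place differs: in compound 1 the trifluoromethyl is para to a large group, whereas in compound 3 it is ortho to a large group. Since the earlier change gave a number 1.7 percentage points lower from compound 1 to compound 2 (within the scatter), compound 4 is expected to show a number 1.5 percentage points lower from compound 3 to compound 4 (within the scatter), a step that would stay within the scatter. On that basis compound 4 is estimated to give 69.5%, most likely between 60% and 78%.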

Compound 4, a percentage reported as activity, at one concentration (the size of the read-out at that concentration, not a potency): 70.7%
For compound 4 the middle estimate is 1.2 percentage points below the measured one; low and high end bracket the measured number.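

In this assay, methoxy in place of trifluoromethyl on an aromatic carbon gave a number 0.3 percentage points lower from compound 3 to compound 4 (within the scatter), 2-methoxyphenyl in place of 4-methoxyphenyl on the aromatic nitrogen gave a number 1.7 percentage points higher from compound 2 to compound 4 (within the scatter), and 2-methoxyphenyl in place of 4-(trifluoromethyl)phenyl on that nitrogen gave no change at the digits printed from compound 1 to compound 4 (within the scatter). The swap of trifluoromethyl for methoxy can be set side by side on the two cores, and the two steps cannot be told apart: the same change on two cores in this assay, a number 1.7 percentage points lower (within the scatter) from compound 1 to compound 2 and a number 0.3 percentage points lower (within the scatter) from compound 3 to compound 4, 1.4 percentage points apart, within the scatter of two such steps. For the compounds shown here, this shows that the change stayed within the scatter on both cores, so nothing in this pair speaks against carrying it from one to the other, but it does not show that the change carries over as an effect of any definite size, since neither step can be told from no step at all, and two cores at a single concentration say nothing about other cores.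

The four compounds carry only trifluoromethyl or methoxy on the phenyl group at the nitrogen, and all of them keep both hydroxy groups. On these data alone, whether an amine or a carboxylic acid on that phenyl group, or a longer chain in place of methoxy, would move the number beyond the scatter stays open.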